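The compounds below may be only part of what the source reports. "The series", "measured", "known", "first", "only" and "open" are said of these compounds alone.

Of the compounds shown here, three with a shared core have been tested so far in a functional assay on EBC-1 cells (Homo sapiens) for antiproliferative activity, with a stated time of 72 h (on this read-out higher numbers stand for weaker inhibition and lower numbers for stronger inhibition), and all give numbers. Compound 1 (`Fc1cc(-c2ccsc2)cn2c(Cc3ccc4ncccc4c3)cnc12`) gives 444 nM there, compound 2 (`N#Cc1ccc(-c2cc(F)c3ncc(Cc4ccc5ncccc5c4)n3c2)cn1`) gives 189 nM and compound 3 (`O=C(c1ccc(-c2cc(F)c3ncc(Cc4ccc5ncccc5c4)n3c2)cc1F)N1CCC2(COC2)C1`) gives 406 nM in the same test. Compound 3 thus lies within the usual scatter of compound 1, while compound 2 has the lowest number of the three. Compound 4 (`O=C(NCC1CCCCN1)c1ccc(-c2cc(F)c3ncc(Cc4ccc5ncccc5c4)n3c2)cc1F`) differs from compound 3 only on a carbonyl carbon, where ((piperidin-2-yl)methyl)amino enters (a group of 8 heavy atoms (6 carbon, 2 nitrogen; one six-membered non-aromatic ring with 1 hetero atom) in place of a group of 8 heavy atoms (6 carbon, 1 nitrogen, 1 oxygen; one four-membered non-aromatic ring with 1 hetero atom, one five-membered non-aromatic ring with 1 hetero atom), on a carbonyl carbon) in place of the earlier group. Going by the values given here, the one measured single-place change, a 2.3-fold lower number from compound 1 to compound 2 (0.37 log units; beyond the scatter) on an aromatic carbon, is modest and happens elsewhere in the molecule, so it offers only a rough size for what one swap can do. Among the compounds with values here, no measured step touches this carbonyl carbon, so no shift beyond the scatter is expected in this assay in either direction. The expected change is an estimated 1.4-fold lower number from compound 3 to compound 4 (0.13 log units; within the scatter) overall. Compound 4 is estimated at 300 nM with an expected range from 90 nM to 900 nM in this test.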

Compound 4, half-maximal inhibitory concentration: 277 nM
Estimate against measurement, compound 4: 1.1-fold (0.03 log units) above; measured number inside the range.
By their numbers in this assay, from the lowest: compounds 2, 4, 3 and 1 (each within the scatter of the next, the first and the last beyond it).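

At this carbonyl carbon, the first measured swap exchanges a group with one four-membered and one five-membered non-aromatic ring for ((piperidin-2-yl)methyl)amino, and in this assay it gives a 1.5-fold lower number from compound 3 to compound 4 (0.17 log units; within the scatter). The number therefore stays within the scatter even though the new group has one six-membered non-aromatic ring and 2 hydrogen-bond donors, where the old group had 0, so these two large groups cannot be told apart in this test. Nothing measured here gives a reason for this result.

On these data alone, both groups are large and contain ring nitrogen, so it remains open whether a small dimethylamino group, or a hydroxyl group that would make a carboxylic acid, would shift the number beyond the scatter. A longer open chain ending in an amine at this carbonyl carbon is equally untested by the compounds shown.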